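This account rests on a few compounds, and the source may have more. Where it says the series, first, only, none or still open, it means among the compounds named here.

Of the compounds shown here, three have been tested in an ADME assay on BJ cells (Homo sapiens), read by MTT assay, with a stated time of 72 h (a lower number here means a stronger inhibitor, a higher number a weaker inhibitor), a measure of how strongly a compound inhibits the growth of these cells. Compound 2, `COc1nc(N)nc2c1c(-c1cccs1)cn2[C@@H]1O[C@H](CO)[C@@H](O)[C@H]1O`, gives 99900 nM in this assay. Compound 1, `COc1nc(N)nc2c1c(-c1ccsc1)cn2[C@@H]1O[C@H](CO)[C@@H](O)[C@H]1O`, differs from compound 2 by thiophen-3-yl in place of thiophen-2-yl on an aromatic carbon. For compound 1 the assay returns only a limit, > 100000 nM. The step of a number no lower from compound 2 to compound 1 (the limit leaves the size open) therefore cannot be sized, because of the limit of > 100000 nM in this assay, at which 2 of the 3 values shown sit. Compound 3, `CNc1ncnc2c1c(-c1cccs1)cn2[C@@H]1O[C@H](CO)[C@@H](O)[C@H]1O`, has a different core; the difference between the two cores is not broken down here. For compound 3 the assay again returns only a limit, > 100000 nM. Compound 4, `CNc1ncnc2c1c(-c1ccsc1)cn2[C@@H]1O[C@H](CO)[C@@H](O)[C@H]1O`, is not yet measured; it differs from compound 3 by thiophen-3-yl in place of thiophen-2-yl on an aromatic carbon, the same change as from compound 2 to compound 1. Since that earlier step left the value at the limit, the expected step is a step that the limit leaves unreadable from compound 3 to compound 4. Compound 4 is thus estimated at 150000 nM, with 70000 nM to 400000 nM as its expected range.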

Compound 4, half-maximal inhibitory concentration: > 100000 nM
Compound 4 was reported as a limit (the forecaster's own chance of this, stated with the estimate: 85%); the middle value is on the limit's open side.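

Compound 3 and compound 4 both sit at a limit of the assay, so no step between them can be read: the limit of > 100000 nM in this assay, at which 3 of the 4 values shown sit.

The compounds shown leave open whether thiophen-3-yl in place of thiophen-2-yl changes the value on this core at all.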